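Dropping the aromatic methyl: from compound 1 to compound 4

A few compounds are considered here, and "the series" means these few. Any claim that something is new, unique, unknown or untested is made for them only; others in the source may bear on it.

Measured compounds:
- compound 1 `Cc1ccc(-n2nc(-c3ccc4ccccc4c3)nc2N2C(=O)C(C)OC23C=CC(=O)C=C3)cc1` gives 530 nM
- compound 2 `CC1CN(c2nc(-c3ccc4ccccc4c3)nn2-c2ccccc2)C2(C=CC(=O)C=C2)O1` gives 260 nM
- compound 3 `Cc1ccc(-n2nc(-c3ccc4ccccc4c3)nc2N2C(=O)COC23C=CC(=O)C=C3)cc1` gives 150 nM

In a functional assay on HeLa cells (Homo sapiens) for antiproliferative activity, with a stated time of 5 days (a higher number here means a weaker inhibitor, a lower number a stronger inhibitor), compound 1 stands highest of the three numbers; compound 2 sits a step below it, and compound 3 lies furthest, as a 3.5-fold lower number from compound 1 to compound 3 (0.55 log units; beyond the scatter) shows. Compound 4 `CC1OC2(C=CC(=O)C=C2)N(c2nc(-c3ccc4ccccc4c3)nn2-c2ccccc2)C1=O` has not yet been measured. It differs from compound 1 by hydrogen in place of methyl on an aromatic carbon, that is, 4-methylphenyl becomes phenyl on the nitrogen that carries the aromatic ring.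

Among the measured compounds shown here, no measured step matches this change. For the measured compounds named here, the only single-point step known, a 3.5-fold lower number from compound 1 to compound 3 (0.55 log units; beyond the scatter), removes a methyl from a saturated ring carbon, a different place, so it gives no direct guide. Compound 2 carries a phenyl and shows a lower number than compound 1, but it differs from compound 1 in more than one place, so its value only hints at a direction. On that basis the expectation for compound 4 is a small step, a 1.5-fold lower number from compound 1 to compound 4 (0.18 log units; within the scatter), possibly within the scatter. The estimate for compound 4 is 350 nM, with a range from 150 nM to 800 nM.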

Compound 4, half-maximal inhibitory concentration: 120 nM
The estimate for compound 4 lay 2.9-fold (0.46 log units) above the measured number, outside the stated range (below it).
By their numbers in this assay, from the lowest: compounds 4, 3 and 2 (each within the scatter of the next, the first and the last beyond it); then compound 1.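

The methyl of the 4-methylphenyl group is not a neutral passenger in this assay: replacing it with hydrogen gives a 4.4-fold lower number from compound 1 to compound 4 (0.65 log units; beyond the scatter), so this aromatic position affects the result even though the change is a single carbon atom. Compound 1 has now lost a methyl at two separate places, and both changes lower the number, since removing the methyl on the saturated ring carbon gives a 3.5-fold lower number from compound 1 to compound 3 (0.55 log units; beyond the scatter). Nothing measured here explains why the aromatic methyl costs activity.

As far as these compounds go, it remains open whether the two methyl removals would add up in one compound. It is also unknown how this aromatic position would respond to a group other than methyl or hydrogen, such as a methoxy group, a chlorine atom or an amine.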